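A few compounds are considered here, and "the series" means these few. Any claim that something is new, unique, unknown or untested is made for them only; others in the source may bear on it.

Measured compounds:
compound 1, `CC1CCCCN1/[N+]([O-])=N/Oc1cc(O/N=[N+](\[O-])N(C)C)c([N+](=O)[O-])cc1[N+](=O)[O-]`: 1500 nM
compound 2, `CN(C)/[N+]([O-])=N/Oc1cc(O/N=[N+](\[O-])N2CCCC2)c([N+](=O)[O-])cc1[N+](=O)[O-]`: 2300 nM

Both compounds were tested in a functional assay on HL-60 cells (Homo sapiens) for antiproliferative activity, read by MTT assay, with a stated time of 72 h; on this read-out lower numbers stand for stronger inhibition and higher numbers for weaker inhibition. Among the compounds with values here, compound 2 gives 2300 nM, and compound 1 gives 1500 nM; the only step that joins them, a 1.5-fold higher number from compound 1 to compound 2 (0.19 log units; within the scatter), so the two numbers are not told apart by this assay. Within the data shown here, the single structural change in that step is an exchange of one cyclic amine for another on a double-bonded nitrogen.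

Compound 3, `CCN(CC)/[N+]([O-])=N/Oc1cc(O/N=[N+](\[O-])N(C)C)c([N+](=O)[O-])cc1[N+](=O)[O-]`, has not yet been measured. It differs from compound 2 in one place: diethylamino in place of pyrrolidin-1-yl on a double-bonded nitrogen. Among the measured compounds shown here, the only measured step that bears on this change is the one from compound 1 to compound 2, which altered the same position and stayed within the scatter. Nothing in the two measured compounds indicates that a further exchange at this position would move the number beyond the scatter, in either direction. Compound 3 is therefore expected to give about 2000 nM in this assay, with a range from 900 nM to 4500 nM. The expected step is a 1.2-fold lower number from compound 2 to compound 3 (0.06 log units; within the scatter), which is no step beyond the scatter.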

Compound 3, half-maximal inhibitory concentration: 1000 nM
Compound 3: the middle estimate sits 2.0-fold (0.30 log units) above what was measured, within the range that was stated.
By their numbers in this assay, from the lowest: compounds 3, 1 and 2 (each within the scatter of the next, the first and the last beyond it).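

In this assay the position on this double-bonded nitrogen now gives a step beyond the scatter, which the earlier pair did not show: the exchange of pyrrolidin-1-yl for diethylamino gives a 2.3-fold lower number from compound 2 to compound 3 (0.36 log units; beyond the scatter), a modest step between two groups with the same count of carbon and nitrogen atoms, one with a ring and one without. The other new step, a 1.5-fold lower number from compound 1 to compound 3 (0.18 log units; within the scatter), stays within the scatter, so diethylamino and 2-methylpiperidin-1-yl are not told apart, and the presence of a ring alone does not separate the compounds, since 2-methylpiperidin-1-yl also has one. Nothing at hand explains why only the exchange from pyrrolidin-1-yl produces a step beyond the scatter.

The three compounds leave open whether the modest step reflects a real trend at this position or a single difference close to the edge of the scatter. They also leave open where groups such as morpholin-4-yl, piperidin-1-yl or dipropylamino would fall on this read-out, and whether the same exchanges would give similar steps with a partner other than dimethylamino on the second double-bonded nitrogen.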